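Trading a cyanophenyl for a chlorophenyl on a flavonol

This account rests on a few compounds, and the source may have more. Where it says the series, first, only, none or still open, it means among the compounds named here.

The series shares one core, a flavonol carrying two free hydroxyls and a benzyl ether, and is judged in an ADME assay on Huh-5-2 cells (Homo sapiens) for cytotoxicity, read by WST assay, with a stated time of 3 days; a lower number here means that less compound is tolerated, a higher number that more compound is tolerated. Compound 1 `O=c1c(OCc2ccccc2Cl)c(-c2ccccc2)oc2cc(O)cc(O)c12` reaches only the limit of this assay, > 100000 nM. Compound 2 `O=c1c(OCc2ccccc2[N+](=O)[O-])c(-c2ccccc2)oc2cc(O)cc(O)c12` gives 51000 nM. Compound 3 `N#Cc1cccc(COc2c(-c3ccccc3)oc3cc(O)cc(O)c3c2=O)c1` gives 21000 nM, the lowest of the two numbers, with a 2.4-fold lower number from compound 2 to compound 3 (0.39 log units; beyond the scatter) and, against the limit, an at least 4.7-fold lower number from compound 1 to compound 3 (0.67 log units; beyond the scatter).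

Compound 4 `O=c1c(OCc2ccc(Cl)cc2)c(-c2ccccc2)oc2cc(O)cc(O)c12` is the next member: 4-chlorophenyl in place of 3-cyanophenyl on a saturated chain carbon bound to an oxygen on an aromatic ring. For the measured compounds named here, two measured steps bear on this change. Both lead to compound 3, and both showed that the 3-cyanophenyl gives a lower number than either a chloro- or a nitro-bearing ring, at least modestly in an at least 4.7-fold lower number from compound 1 to compound 3 (0.67 log units; beyond the scatter) and modestly in a 2.4-fold lower number from compound 2 to compound 3 (0.39 log units; beyond the scatter). Returning to a chlorine-bearing ring in compound 4 should therefore reverse that direction, even though the chlorine now sits in a different place on the ring; compound 1, the other chloro compound, sits at the limit (the limit of > 100000 nM in this assay, at which 1 of the 3 values shown sits).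

The expected step is a 2.9-fold higher number from compound 3 to compound 4 (0.46 log units; beyond the scatter), upward. Compound 4 is estimated at 60000 nM, within a range from 25000 nM to 150000 nM.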

Compound 4, half-maximal cytotoxic concentration: 36000 nM
Beside the measured number, compound 4's estimate is 1.7-fold (0.22 log units) above it, and the stated range covers the measured number.
By their numbers in this assay, from the lowest: compounds 3, 4 and 2 (each within the scatter of the next, the first and the last beyond it). At a limit, above all of these: compound 1.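

In this assay, the 2-chlorophenyl and the 4-chlorophenyl are not interchangeable at this position, on a saturated chain carbon bound to an oxygen on an aromatic ring: the step reads an at least 2.7-fold lower number from compound 1 to compound 4 (0.44 log units; beyond the scatter). The presence of a chlorine on the ring therefore does not settle the number on its own, and where the chlorine sits makes a difference among these compounds. Compound 4 also cannot be separated from either of its other neighbours, with a 1.7-fold higher number from compound 3 to compound 4 (0.23 log units; within the scatter) and a 1.4-fold lower number from compound 2 to compound 4 (0.15 log units; within the scatter), both inside the scatter, even though compound 2 and compound 3 lie beyond the scatter of each other.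

Compound 1 stays at a limit, so its true distance from the others remains unknown, and the first step above gives only a floor: the limit of > 100000 nM in this assay, at which 1 of the 4 values shown sits.

The compounds shown leave open how the number would respond to an amine or a carboxylic acid on the ring in place of the chlorine. They also leave open what a longer chain would do in place of the saturated chain carbon that carries the ring.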